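This account rests on a few compounds, and the source may have more. Where it says the series, first, only, none or still open, it means among the compounds named here.

Measured so far in a functional assay for inhibition, with Homo sapiens as the target; on this read-out higher numbers stand for weaker inhibition and lower numbers for stronger inhibition:
- compound 1 `C=CCn1ncc2cnc(COC)n2c1=O`: > 48000 nM
- compound 2 `C=CCn1ncc2c(C)nc(C)n2c1=O`: 73000 nM

The value for compound 1 is a limit of the assay and not a number. Compound 2 is the only compound with an actual number in this assay; the other result shown is a limit (the limit of > 48000 nM in this assay, at which 1 of the 2 values shown sits). So compound 2 stands as the one fixed point here, and it is a weak inhibitor.

Compound 3 `C=CCn1ncc2cnc(C)n2c1=O` has not yet been measured. It differs from compound 2 in a single place: hydrogen in place of methyl on an aromatic carbon, in words, hydrogen in place of methyl on an aromatic carbon. Going by the values given here, no pair of measured compounds shows what removing this methyl does, so there is nothing to say whether it helps or hurts. The step from compound 2 to compound 3 is therefore expected to be small, a 1.0-fold higher number from compound 2 to compound 3 (0.01 log units; within the scatter), staying within the usual scatter. Compound 3 is expected to give about 75000 nM in this assay, somewhere between 30000 nM and 200000 nM, with a real chance that only a limit is reported.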

Compound 3, half-maximal inhibitory concentration: > 48000 nM
Compound 3 was reported as a limit; the forecaster's own chance of this, stated with the estimate: 55%; the middle value does not contradict the limit.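

In this assay compound 3 gives > 48000 nM as a limit and not a number. No step can be read from compound 2 to compound 3 or from compound 1 to compound 3. The compounds shown leave open how much inhibition changes when hydrogen replaces methyl on an aromatic carbon, or methoxy on a saturated chain carbon.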